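This account rests on a few compounds, and the source may have more. Where it says the series, first, only, none or still open, it means among the compounds named here.

For the measured compounds named here, in a functional assay on RS4-11 cells (Homo sapiens) for inhibition, read by CCK-8 assay, with a stated time of 48 h, tested at 20 uM (on this read-out lower numbers stand for less inhibition of growth and higher numbers for more inhibition of growth at the one concentration tested), compound 2 `N#C/C(=C\c1ccccc1OS(=O)(=O)c1ccc([N+](=O)[O-])cc1)C(=O)Nc1nnc(Cc2cccc3ccccc23)s1` gives 58%, the lower of the two numbers so far, against compound 1 `Cc1ccc(S(=O)(=O)Oc2ccccc2/C=C(\C#N)C(=O)Nc2nnc(Cc3cccc4ccccc34)s2)cc1` at 73%. Going by the values given here, the only measured step, a number 15 percentage points lower from compound 1 to compound 2 (beyond the scatter), is nitro in place of methyl on an aromatic carbon, elsewhere in the molecule, so it gives only a rough size for steps. Compound 3 `N#C/C(=C\c1ccccc1OS(=O)(=O)c1ccc([N+](=O)[O-])cc1)C(=O)Nc1nnc(Cc2cccc(F)c2)s1` carries 3-fluorophenyl in place of naphthalen-1-yl on a saturated chain carbon bound to an aromatic carbon, 3-fluorophenyl in place of naphthalen-1-yl on a saturated chain carbon bound to an aromatic carbon. Among the compounds with values here, no measured step covers this change. A modest fall in this assay is expected, the estimated step being a number 13 percentage points lower from compound 2 to compound 3 (beyond the scatter). For compound 3 the estimate is 45%, within 25% to 65%.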

Compound 3, percent growth inhibition at one concentration: 65%
For compound 3 the middle estimate is 20 percentage points below the measured one, and the stated range covers the measured number.
By their numbers in this assay, from the lowest: compounds 2, 3 and 1 (each within the scatter of the next, the first and the last beyond it).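

In this assay the change from naphthalen-1-yl to 3-fluorophenyl gives a number 7 percentage points higher from compound 2 to compound 3 (within the scatter) and so separates neither group on this read-out. On a saturated chain carbon bound to an aromatic carbon, one aromatic ring of carbon only thus reads the same as two when the nitro group is present. No evidence on hand bears on this result.

Still open, as far as these compounds go, is whether plain phenyl or 3-methoxyphenyl at this place would read like 3-fluorophenyl. Also open, from the compounds shown here alone, is whether the same change reads alike with methyl in place of nitro.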